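Oxan-4-yl for cyclohexyl on the pyrazolopyrimidine series

A few compounds are considered here, and "the series" means these few. Any claim that something is new, unique, unknown or untested is made for them only; others in the source may bear on it.

Compound 1 `Nc1ncnc2c1c(-c1cc(C3CC3)on1)nn2C1CCCCC1` is the reference of the set. In an assay on BaF3 cells for inhibition of proto-oncogene tyrosine-protein kinase receptor Ret variant V804M (Homo sapiens), read by MTT assay, with a stated time of 48 h (on this read-out lower numbers stand for stronger inhibition of growth and higher numbers for weaker inhibition of growth), compound 1 gives 2000 nM, the lowest of the two numbers recorded. The nearest measured analogue, compound 3 `CC(C)n1nc(-c2cc(-c3ccccc3)on2)c2c(N)ncnc21`, gives 4970 nM in this assay, a gap that lies beyond the scatter. Compound 2 `CC(C)n1nc(/C=N/OCc2ccccc2)c2c(N)ncnc21` returns only a limit in this assay, > 10000 nM, which is the limit of > 10000 nM in this assay, at which 1 of the 3 values shown sits.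

Compound 4 `Nc1ncnc2c1c(-c1cc(C3CC3)on1)nn2C1CCOCC1` is not yet measured. It differs from compound 1 by oxan-4-yl in place of cyclohexyl on an aromatic nitrogen. Among the measured compounds shown here, no measured pair in the set follows this change, so no direction is established from the data. The step is expected to stay within the scatter, a 1.3-fold higher number from compound 1 to compound 4 (0.10 log units; within the scatter), with a slight loss if anything. Compound 4 is therefore estimated at 2500 nM in this assay, between 1000 nM and 6300 nM.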

Compound 4, concentration for 50% growth inhibition: 1930 nM
Beside the measured number, compound 4's estimate is 1.3-fold (0.11 log units) above it, and the stated range covers the measured number.
By their numbers in this assay, from the lowest: compounds 4 and 1 (each within the scatter of the next); then compound 3. At a limit, above all of these: compound 2.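

Among the compounds shown here, on the aromatic nitrogen, oxan-4-yl in place of cyclohexyl is the only one-place step so far, and in this assay it stays within the scatter (a 1.0-fold lower number from compound 1 to compound 4 (0.02 log units; within the scatter)). A ring oxygen and its hydrogen-bond acceptor therefore do not separate the two compounds here, with the 5-cyclopropyl-1,2-oxazol-3-yl group held fixed. No measured property bears on this result.

Open, from the compounds shown here alone, is whether a piperidin-4-yl ring with its amine, or a longer chain ending in a carboxylic acid, would read alike on this nitrogen. Also open, going by these compounds, is whether the same exchange holds with another group on the oxazole.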